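Trifluoromethyl to methoxy in a series near its limit

A few compounds are considered here, and "the series" means these few. Any claim that something is new, unique, unknown or untested is made for them only; others in the source may bear on it.

Values in a functional assay on MCF7 cells (Homo sapiens) for inhibition, read by sulforhodamine B assay (a higher number here means a weaker inhibitor, a lower number a stronger inhibitor), stand as follows:
compound 1 `O=C1C(Nc2ccc(Br)cc2)=CC(=O)c2c1nc1n2[C@H]2OC[C@@H](O)[C@H]2OC1` gives 4330 nM
compound 2 `Cc1ccc(NC2=CC(=O)c3c(nc4n3[C@H]3OC[C@@H](O)[C@H]3OC4)C2=O)cc1` gives > 4000 nM as a limit
compound 3 `O=C1C(Nc2ccc(C(F)(F)F)cc2)=CC(=O)c2c1nc1n2[C@H]2OC[C@@H](O)[C@H]2OC1` gives > 4000 nM as a limit

Compound 3 stands only at a limit (> 4000 nM). Compound 4 `COc1ccc(NC2=CC(=O)c3c(nc4n3[C@H]3OC[C@@H](O)[C@H]3OC4)C2=O)cc1` differs from it by methoxy in place of trifluoromethyl on an aromatic carbon. For the measured compounds named here, three measured steps bear on this change: a step that the limit leaves unreadable from compound 1 to compound 2 and a step that the limit leaves unreadable from compound 1 to compound 3 and a step that the two limits leave unreadable from compound 2 to compound 3. None has a readable size, so no step beyond the scatter is expected, and no direction. Going by the values given here, the only actual number is that of compound 1 (4330 nM). The estimated change in this assay is a step that the limit leaves unreadable from compound 3 to compound 4 and is expected to stay small. For compound 4 the expected value is 5000 nM (estimated range 2500 nM to 12000 nM).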

Compound 4, half-maximal inhibitory concentration: 4470 nM
For compound 4 the middle estimate is 1.1-fold (0.05 log units) above the measured one, and the stated range covers the measured number.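

In this assay, methoxy in place of bromo at this position gives a 1.0-fold higher number from compound 1 to compound 4 (0.01 log units; within the scatter), the only readable step among the compounds shown. This assay therefore does not tell these two groups apart on this aromatic carbon. The steps from compound 2 and compound 3 to compound 4 cannot be read, because those two compounds stand only at a limit: the limit of > 4000 nM in this assay, at which 2 of the 4 values shown sit.

From the compounds shown here alone, how far methyl or trifluoromethyl lies from methoxy at this position stays open. So does whether an amine or a carboxylic acid there would give a number beyond the scatter of these values.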